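Swapping methylsulfanyl for cyclopropyl on a benzyl ring

The source may hold more compounds than are shown below. What is called first, only, known or untested is meant among the compounds shown, and "the series" means these compounds.

Measured compounds:
- compound 1, `COc1cccc(NC(=O)c2nnn(Cc3ccc(SC)cc3)c2N)c1`: < 12000 nM
- compound 2, `COc1cccc(NC(=O)c2nnn(Cc3ccccc3)c2N)c1`: 16000 nM
- compound 3, `COc1cccc(NC(=O)c2nnn(CC3CCN(C(=O)OC(C)(C)C)CC3)c2N)c1`: 39000 nM

The three compounds share one core and differ only in the group carried on the benzylic side. In a physicochemical assay for solubility, read by nephelometry, at pH 7.4 (a higher number here means a more soluble compound, a lower number a less soluble compound), compound 1 reaches only a limit, < 12000 nM, so no exact number is known for it. Compound 2 gives 16000 nM in this assay, and compound 3 gives 39000 nM.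

Compound 4, `COc1cccc(NC(=O)c2nnn(Cc3ccc(C4CC4)cc3)c2N)c1`, differs from compound 1 in one place: cyclopropyl in place of methylsulfanyl on an aromatic carbon. Within the data shown here, the only measured step that touches this part of the molecule is an at least 1.3-fold higher number from compound 1 to compound 2 (0.12 log units; that floor lies within the scatter), and its floor lies within the scatter, so it says little about the size of the effect. The limit for compound 1 is recorded as the limit of < 12000 nM in this assay, at which 1 of the 3 values shown sits. A cyclopropyl in place of methylsulfanyl keeps a small carbon group of comparable size on the same ring position, so the expectation is a step of roughly a step that the limit leaves unreadable from compound 1 to compound 4, that is, no change beyond the scatter. Compound 4 is therefore estimated at 9000 nM, with a range from 3500 nM to 20000 nM.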

Compound 4, solubility: 79000 nM
For compound 4 the middle estimate is 8.8-fold (0.94 log units) below the measured one; measured number outside the range, above it.
By their numbers in this assay, from the lowest: compound 2; then compound 3; then compound 4. At a limit, below all of these: compound 1.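

In this assay the group on this aromatic carbon proves to matter beyond the scatter, which the earlier step could not show: cyclopropyl in place of methylsulfanyl gives an at least 6.5-fold higher number from compound 1 to compound 4 (0.81 log units; beyond the scatter) on this comparison. Cyclopropyl in place of hydrogen gives a 4.9-fold higher number from compound 2 to compound 4 (0.69 log units; beyond the scatter) with no limit involved, so adding this group to the bare ring goes with a higher number, not a lower one. The reading for compound 1 is a limit, so the first of these steps is only a floor: the limit of < 12000 nM in this assay, at which 1 of the 4 values shown sits.

The compounds shown leave open whether the rise is particular to cyclopropyl or would also appear with another group at this place, such as an ethyl chain or an amine. They also leave open how a carboxylic acid on this ring would read.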